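The source may hold more compounds than are shown below. What is called first, only, known or untested is meant among the compounds shown, and "the series" means these compounds.

Compound 2 `O=C([C@@H]1C[C@H](N2CCN(c3cccc(Cl)c3)CC2)CN1)N1CCSC1` carries a 3-chlorophenyl on the amine nitrogen in a ring of the shared core; in an assay on a cell-free system (plasma) for inhibition of Dipeptidyl peptidase 4 (Rattus norvegicus), read by fluorescence (on this read-out higher numbers stand for weaker inhibition and lower numbers for stronger inhibition), compound 2 gives 7.2 nM. Among the compounds with values here, that is the higher of the two numbers measured so far: compound 1 `N#Cc1ccnc(N2CCN([C@@H]3CN[C@H](C(=O)N4CCSC4)C3)CC2)c1` gives in this assay 1.9 nM, and the step of a 3.8-fold higher number from compound 1 to compound 2 (0.58 log units; beyond the scatter) is the only recorded one. Compound 3 `O=C([C@@H]1C[C@H](N2CCN(c3ccc(Cl)cc3)CC2)CN1)N1CCSC1` is not yet measured in this assay. It differs from compound 2 by 4-chlorophenyl in place of 3-chlorophenyl on an amine nitrogen in a ring. Within the data shown here, the one measured step bears on this only indirectly: it shows that the group on this ring nitrogen moves the number, but it exchanges one aryl for a different one rather than moving a chlorine within the same ring. Among the measured compounds shown here, no measured pair shows a chlorine shifted around a phenyl, so there is no direct precedent for size or direction. A change smaller than a 3.8-fold higher number from compound 1 to compound 2 (0.58 log units; beyond the scatter) is therefore expected, most likely within the scatter, in either direction. Compound 3 is expected to give 6.5 nM in this assay, within a range from 2.2 nM to 20 nM. The expected step of a 1.1-fold lower number from compound 2 to compound 3 (0.04 log units; within the scatter) is small.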

Compound 3, half-maximal inhibitory concentration: 10.3 nM
Compound 3: the middle estimate sits 1.6-fold (0.20 log units) below what was measured; low and high end bracket the measured number.
By their numbers in this assay, from the lowest: compound 1; then compounds 2 and 3 (each within the scatter of the next).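

In this assay, moving the chlorine around the phenyl gives a step that stays small (a 1.4-fold higher number from compound 2 to compound 3 (0.16 log units; within the scatter)), so this pair does not separate 4-chlorophenyl from 3-chlorophenyl on the amine nitrogen in a ring. Placing 4-chlorophenyl where compound 1 has 4-cyanopyridin-2-yl gives a step beyond the scatter (a 5.4-fold higher number from compound 1 to compound 3 (0.73 log units; beyond the scatter)), as the 3-chlorophenyl exchange does (a 3.8-fold higher number from compound 1 to compound 2 (0.58 log units; beyond the scatter)), so the gap from compound 1 is not confined to one chlorine placement among the two tested. No supporting information on these compounds accounts for either the small step or the larger ones.

The compounds shown leave open which part of 4-cyanopyridin-2-yl goes with the lower number in compound 1, since the exchange to either chlorophenyl alters the ring and its substituent in one step. A 4-cyanophenyl or an unsubstituted pyridin-2-yl on the same nitrogen would separate the nitrile from the ring nitrogen, and would show whether either one alone accounts for the gap between compound 1 and the two chlorophenyl compounds.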